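The source may report more compounds than this note shows. Statements on the series, on what has been measured and on what is new or still open speak of the compounds shown alone.

Series notes on three measured analogues and one pending. Compound 1 `Oc1ccc(-c2ccc(-c3ccc(-c4nc5ccccc5[nH]4)cc3)cc2)cc1` is the reference in a functional assay on HOP-62 cells (Homo sapiens) for inhibition, read by sulforhodamine B assay (on this read-out higher numbers stand for weaker inhibition of growth and lower numbers for stronger inhibition of growth), where compound 1 gives 47200 nM as its number. Compound 2 `COc1ccc(-c2ccc(-c3ccc(-c4nc5ccccc5[nH]4)cc3)cc2)cc1` carries the change methyl in place of hydrogen on an oxygen on an aromatic ring relative to compound 1, and in this assay compound 2 gives 100000 nM, so that the step of a 2.1-fold higher number from compound 1 to compound 2 (0.33 log units; beyond the scatter) is the one reference point for this change. Compound 3 `Oc1ccc(-c2ccc(-c3ccc(-c4nc5c(O)cccc5[nH]4)cc3)cc2)cc1` differs from compound 1 by hydroxy in place of hydrogen on an aromatic carbon on the core, and in this assay compound 3 gives 2410 nM, the step of a 20-fold lower number from compound 1 to compound 3 (1.29 log units; beyond the scatter) being the large one in the set. Compound 4 `COc1ccc(-c2ccc(-c3ccc(-c4nc5c(O)cccc5[nH]4)cc3)cc2)cc1` is not yet measured. It relates to compound 3 as compound 2 relates to compound 1, namely by methyl in place of hydrogen on an oxygen on an aromatic ring on the same kind of place, so this change occurs twice in the set. The cores of the two pairs differ by the hydroxy change already described for compound 3. The step from compound 3 to compound 4 in this assay is expected to be a 2.1-fold higher number from compound 3 to compound 4 (0.32 log units; beyond the scatter), of about the size of the earlier step of a 2.1-fold higher number from compound 1 to compound 2 (0.33 log units; beyond the scatter), resting on that single precedent only. Compound 4 is accordingly estimated at 5000 nM in this assay, with a likely range from 2400 nM to 12000 nM for that number.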

Compound 4, concentration for 50% growth inhibition: 3210 nM
Compound 4: middle estimate off by 1.6-fold (0.19 log units), on the high side, within the range that was stated.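

In this assay, hydroxy to methoxy on the core bearing the extra hydroxy gives a 1.3-fold higher number from compound 3 to compound 4 (0.12 log units; within the scatter), and this step does not differ from its earlier counterpart beyond the scatter: the same change on two cores in this assay, a 2.1-fold higher number (0.33 log units; beyond the scatter) from compound 1 to compound 2 and a 1.3-fold higher number (0.12 log units; within the scatter) from compound 3 to compound 4, 1.6-fold (0.20 log units) apart, within the scatter of two such steps. The hydroxy change on the core also carries over from the hydroxy-bearing to the methoxy-bearing pair, with a 31-fold lower number from compound 2 to compound 4 (1.49 log units; beyond the scatter), again without a difference beyond the scatter: the same change on two cores in this assay, a 20-fold lower number (1.29 log units; beyond the scatter) from compound 1 to compound 3 and a 31-fold lower number (1.49 log units; beyond the scatter) from compound 2 to compound 4, 1.6-fold (0.20 log units) apart, within the scatter of two such steps. Within these four compounds, the two changes therefore behave as additive, but each comparison rests on only two steps in this assay, so this does not show that either change would transfer to other cores, other groups or other read-outs.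

On these data alone, it remains open whether the effect of the hydroxy on the core would persist if that hydroxy were replaced by a methoxy or an amine. As far as these compounds go, it is equally open whether a longer chain in place of the methyl on the oxygen would leave the number as little changed as in a 1.3-fold higher number from compound 3 to compound 4 (0.12 log units; within the scatter).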